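Swapping a thiophene arm for a methoxypyrazine

The source may report more compounds than this note shows. Statements on the series, on what has been measured and on what is new or still open speak of the compounds shown alone.

Measured so far:
Compound 1, `CCN1CCN(c2cccc3c2CN([C@H](CCCNCc2cccs2)c2ccc(OC)c(OC)c2)C3=O)CC1`: 59 nM
Compound 2, `COc1ccc([C@@H](CCCN(C)S(=O)(=O)c2cccs2)N2Cc3c(cccc3N3CCN(C)CC3)C2=O)cc1OC`: 340 nM
Compound 3, `COc1ccc([C@@H](CCCN(C)S(=O)(=O)c2cccs2)N2Cc3c(cccc3N3CCN(C4CC4)CC3)C2=O)cc1OC`: 1200 nM

In a functional assay on RMS13 cells for antagonist activity at Urotensin-2 receptor (Homo sapiens), read by FLIPR and calcium flux, with a stated time of 1 h (a lower number here means a stronger inhibitor, a higher number a weaker inhibitor), compound 1 gives the lowest of the three numbers; compound 2 sits higher, and compound 3 higher still. The only one-place step among these, a 3.5-fold higher number from compound 2 to compound 3 (0.55 log units; beyond the scatter), concerns an amine nitrogen in a ring on the shared core and does not touch the side of the molecule changed here. Compound 2 and compound 3 differ from compound 1 in more than one place, so their numbers show only the spread, not a rule.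

Compound 4, `CCN1CCN(c2cccc3c2CN([C@H](CCCNc2cncc(OC)n2)c2ccc(OC)c(OC)c2)C3=O)CC1`, differs from compound 1 by 6-methoxypyrazin-2-yl in place of (thiophen-2-yl)methyl on an amine nitrogen. For the measured compounds named here, no measured pair informs this change, so the expectation rests on compound 1 alone with wide uncertainty. A small weakening is expected, a 2.5-fold higher number from compound 1 to compound 4 (0.41 log units; beyond the scatter), possibly within the scatter. Compound 4 is estimated at 150 nM, with a range from 40 nM to 600 nM.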

Compound 4, half-maximal inhibitory concentration: 62 nM
Beside the measured number, compound 4's estimate is 2.4-fold (0.38 log units) above it; low and high end bracket the measured number.
By their numbers in this assay, from the lowest: compounds 1 and 4 (each within the scatter of the next); then compound 2; then compound 3.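

In this assay, the step is a 1.1-fold higher number from compound 1 to compound 4 (0.02 log units; within the scatter), so this one pair shows that (thiophen-2-yl)methyl and 6-methoxypyrazin-2-yl on this amine nitrogen give numbers that cannot be told apart, although a five-membered aromatic ring gives way to a larger, six-membered one with more hydrogen-bond acceptors. For the compounds shown here, this is the first measured change at this amine nitrogen, as the earlier one-place step concerned an amine nitrogen in a ring on the shared core. No available evidence explains why two such different groups read alike here.

Still open, going by these compounds, is how other groups would fare on this nitrogen, such as a plain phenyl ring, a benzyl group or a longer chain. It is also unknown whether 6-methoxypyrazin-2-yl would read the same with methyl or cyclopropyl in place of the ethyl group on the ring amine nitrogen.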